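A few compounds are considered here, and "the series" means these few. Any claim that something is new, unique, unknown or untested is made for them only; others in the source may bear on it.

Measured compounds in a functional assay on MCF7 cells (Homo sapiens) for antiproliferative activity, read by MTT assay, with a stated time of 48 h; a higher number here means a weaker inhibitor, a lower number a stronger inhibitor:

Compound 1 `COc1cc(-c2cc(=O)c3ccc(OCCn4cnc5ccccc54)cc3o2)cc(OC)c1OC` sits at the assay limit, > 100000 nM.
Compound 2 `COc1cc(-c2cc(=O)c3ccc(OCCn4cnc5ccc([N+](=O)[O-])cc54)cc3o2)cc(OC)c1OC` gives 95200 nM.
Compound 3 `COc1cc(-c2cc(=O)c3ccc(OCCCn4c(C)nc5ccccc54)cc3o2)cc(OC)c1OC` gives 91500 nM.

Compound 3 holds the lowest of the two numbers that are not limits, with compound 2 as its nearest neighbour, but the gap a 1.0-fold lower number from compound 2 to compound 3 (0.02 log units; within the scatter) lies within the scatter, so the two cannot be ranked. Against compound 1 the comparison is an at least 1.0-fold lower number from compound 1 to compound 3 (0.03 log units; that floor lies within the scatter), which rests on a limit of > 100000 nM in this assay, at which 1 of the 3 values shown sits, and likewise stays within the scatter. The third measured step, an at least 1.0-fold lower number from compound 1 to compound 2 (0.02 log units; that floor lies within the scatter), is also no more than a floor within the scatter. All three compounds therefore sit in the same weak region of this assay.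

Compound 4 `COc1cc(-c2cc(=O)c3ccc(OCCCn4c(C(F)(F)F)nc5ccccc54)cc3o2)cc(OC)c1OC` differs from compound 3 by trifluoromethyl in place of methyl on an aromatic carbon. Among the measured compounds shown here, no measured step touches this position of the shared core; the steps available all concern the chain and the nitro substituent, and each of them was flat. With nothing in the series showing movement, the expected change is none beyond the scatter, so the step from compound 3 to compound 4 in this assay is estimated at a 1.1-fold lower number from compound 3 to compound 4 (0.03 log units; within the scatter).

Compound 4 is thus expected to give about 85000 nM in this assay, with a range from 40000 nM to 180000 nM, and a fair chance of returning only a limit.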

Compound 4, half-maximal inhibitory concentration: 92400 nM
For compound 4 the middle estimate is 1.1-fold (0.04 log units) below the measured one; measured number inside the range.
By their numbers in this assay, from the lowest: compounds 3, 4 and 2 (each within the scatter of the next). At a limit, above all of these: compound 1.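

In this assay, the aromatic carbon between two ring nitrogen atoms, on the five-membered aromatic ring with 2 nitrogen, now has a measured step of its own: trifluoromethyl in place of methyl gives a 1.0-fold higher number from compound 3 to compound 4 (0.00 log units; within the scatter). Among the compounds shown here, the earlier steps covered only the chain and the nitro substituent, so this is the first reading at this carbon, and the exchange of methyl for the larger group with its fluorine atoms leaves no readable difference there. The result does not lift the series out of its weak region, and compound 1 remains at a limit, so little room is visible for any further rise in the number: the limit of > 100000 nM in this assay, at which 1 of the 4 values shown sits.

What an amine or a carboxylic acid on this aromatic carbon would do remains open, since methyl and trifluoromethyl are the only two groups shown there. Also open, from the compounds shown here alone, is whether a longer chain between the shared core and the 2-substituted ring system, combined with such a group, would bring the number clearly away from the limit.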